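Hydroxy for oxadiazolyl on the carbonyl: step to compound 4

This account rests on a few compounds, and the source may have more. Where it says the series, first, only, none or still open, it means among the compounds named here.

compound 1 `CCN1CCc2c(sc(NC(=O)Nc3ccc(Cl)cc3)c2C(=O)c2nnco2)C1`: > 25000 nM
compound 2 `CCN1CCc2c(sc(NC(=O)Nc3ccc(I)cc3)c2C(N)=O)C1`: 1620 nM
compound 3 `CCCN1CCc2c(sc(NC(=O)Nc3ccc(Cl)cc3)c2C(N)=O)C1`: 3500 nM

All three were read in a functional assay (strain AB) with Danio rerio as the target, read by microscopy, with a stated time of 1 h; on this read-out lower numbers stand for an effect already at smaller amounts and higher numbers for an effect only at larger amounts of compound. For compound 1 the value of > 25000 nM is a limit of the assay and not a number, the single case of the limit of > 25000 nM in this assay, at which 1 of the 3 values shown sits. Among the compounds with values here, compound 2 gives 1620 nM, and compound 3 gives 3500 nM; neither differs from compound 1 in only one place, so no step to them is computed.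

Compound 4 `CCN1CCc2c(sc(NC(=O)Nc3ccc(Cl)cc3)c2C(=O)O)C1` is not yet measured. It differs from compound 1 by hydroxy in place of 1,3,4-oxadiazol-2-yl on a carbonyl carbon. Since compound 1 stands only at a limit, the step of an at least 2.0-fold lower number from compound 1 to compound 4 (0.31 log units; beyond the scatter) is expected to be uncertain in size, a move toward a measurable number being possible but not assured. Compound 4 is estimated at 12000 nM, within 2500 nM to 60000 nM.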

Compound 4, half-maximal effective concentration: > 25000 nM
Compound 4: no number, only a limit; the forecaster's own chance of this, stated with the estimate: 45%; middle value at least 2.0-fold (0.31 log units) from the limit.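

Within the data shown here, compound 1 and compound 4 both stand only at a limit of the assay, and no step between them can be read. The compounds shown leave open how hydroxy and 1,3,4-oxadiazol-2-yl on a carbonyl carbon compare in this assay on this core.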